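Swapping a hydroxy for an amino on two stilbene-like scaffolds

A few compounds are considered here, and "the series" means these few. Any claim that something is new, unique, unknown or untested is made for them only; others in the source may bear on it.

Measured compounds:
Compound 1 `Oc1ccc(/C=C/c2cccc(O)c2)cc1`: 6.9 ug/mL
Compound 2 `COc1ccccc1/C=C/c1ccccc1O`: 23 ug/mL
Compound 3 `Nc1cccc(/C=C/c2ccc(O)cc2)c1`: 51 ug/mL

All three were tested in a functional assay on HT-29 cells (Homo sapiens) for inhibition, read by MTT assay, with a stated time of 2 days; on this read-out lower numbers stand for stronger inhibition and higher numbers for weaker inhibition. Compound 1 gives 6.9 ug/mL there, compound 3 gives 51 ug/mL and compound 2 gives 23 ug/mL. Compound 2 stands between the other two, above compound 3 and above compound 1 as well, each gap beyond the scatter.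

Compound 3 differs from compound 1 by one change, (amino in place of hydroxy on an aromatic carbon). That change made the step of a 7.4-fold higher number from compound 1 to compound 3 (0.87 log units; beyond the scatter), a weakening of inhibition that is modest but clearly beyond the scatter.

Compound 4 `COc1ccccc1/C=C/c1ccccc1N` has not yet been measured. It differs from compound 2 by amino in place of hydroxy on an aromatic carbon. Going by the values given here, this is the same kind of change as the one from compound 1 to compound 3, but not the same: in compound 3 the amino sits meta to a group of 9 heavy atoms, whereas in compound 4 it sits ortho to a large group. The difference between the core of compound 1 and the core of compound 2 is not broken down here.

Because a 7.4-fold higher number from compound 1 to compound 3 (0.87 log units; beyond the scatter) weakened inhibition on the core of compound 1, a weakening of a similar, somewhat smaller size is expected for compound 4, namely a 4.3-fold higher number from compound 2 to compound 4 (0.64 log units; beyond the scatter). Compound 4 is therefore estimated at 100 ug/mL in this assay, with a likely range from 40 ug/mL to 300 ug/mL.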

Compound 4, half-maximal inhibitory concentration: > 100 ug/mL
Compound 4 ended at the assay's limit (the forecaster's own chance of this, stated with the estimate: 30%); the middle value sits exactly at the limit.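

In this assay compound 4 gives > 100 ug/mL, which is a limit of the assay and not a number. Amino in place of hydroxy on an aromatic carbon, here ortho to a large group, gives an at least 4.3-fold higher number from compound 2 to compound 4 (0.63 log units; beyond the scatter), a weakening of inhibition, and the same change also weakened inhibition on the other core, so the direction carries over in these two cases. Whether the size of the effect carries over as well is not shown, since the true value for the second step could lie anywhere past the limit: the same change on two cores in this assay, a 7.4-fold higher number (0.87 log units; beyond the scatter) from compound 1 to compound 3 and an at least 4.3-fold higher number (0.63 log units; beyond the scatter) from compound 2 to compound 4; the limit leaves it open whether they differ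

Two cores are too few to say whether the same swap would weaken inhibition on a third core, and the pair of steps says nothing about why the amino does worse than the hydroxy. Also open, as far as these compounds go, is whether the loss belongs to the amino group alone or would also appear with another group in the same place, such as a fluorine, an acetamide or a carboxylic acid.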